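The compounds below may be only part of what the source reports. "The series", "measured", "known", "first", "only" and "open" are said of these compounds alone.

Compound 1 `O=C1COc2ccc(-c3nn(-c4ccc(Br)cc4)cc3-c3ccccc3)cc2N1`: 91.5%
Compound 2 `O=C1COc2ccc(-c3[nH]c(-c4c[nH]c5ncccc45)nc3-c3ccccc3)cc2N1`: 8.9%

In a functional assay on MV4-11 cells (Homo sapiens) for cytotoxicity, read by colorimetric assay and MTT assay, with a stated time of 3 days, tested at 20 uM (a lower number here means a stronger effect, a higher number a weaker effect of the compound at the concentration tested), compound 1 gives 91.5%, the higher of the two numbers at hand and therefore the weaker effect at the concentration tested. Compound 2 gives 8.9% in the same assay, a number far lower and beyond the scatter. Among the compounds with values here, compound 2 differs from compound 1 in more than one place, so no single step links the two; their values show only that a strong effect is reachable on the shared core, while compound 1 stays near the weak end.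

Compound 3 `O=C1COc2ccc(-c3nn(-c4ccc(F)cc4)cc3-c3ccccc3)cc2N1` has not yet been measured. It differs from compound 1 by fluoro in place of bromo on an aromatic carbon. Within the data shown here, no measured pair shows what a swap between these two halogens does on this core, so the anchor is compound 1 alone. The step from compound 1 to compound 3 is expected to be small, a number 3.5 percentage points lower from compound 1 to compound 3 (within the scatter), with no change beyond the scatter. For compound 3 the estimate in this assay is therefore 88%, within a range from 65% to 100%.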

Compound 3, a percentage reported as activity, at one concentration (the size of the read-out at that concentration, not a potency): 92.6%
Estimate against measurement, compound 3: 4.6 percentage points below; low and high end bracket the measured number.
By their numbers in this assay, from the lowest: compound 2; then compounds 1 and 3 (each within the scatter of the next).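

Within the data shown here, the step of a number 1.1 percentage points higher from compound 1 to compound 3 (within the scatter) in this assay is the first that can be read on this core, and it shows that 4-bromophenyl and 4-fluorophenyl leave compound 1 and compound 3 level within the scatter. At this place, on an aromatic carbon para to a large group, exchanging one halogen for the other therefore gives no change that the assay can separate from repeat variation, and both compounds show only a weak effect at the concentration tested. No measurement of any other kind bears on this result, and the data offer no explanation for it.

The compounds shown leave open whether a group other than a halogen at this place, such as an amine, a carboxylic acid or a longer chain, would shift the read-out beyond the scatter. They also leave open which of the several places where compound 2 differs from compound 1 accounts for the far lower number of compound 2, as no single step links the two.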